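Ring-nitrogen substituents on a trifluoromethoxy benzothiazole imine series

A few compounds are considered here, and "the series" means these few. Any claim that something is new, unique, unknown or untested is made for them only; others in the source may bear on it.

Measured compounds:
compound 1, `Nc1nc2ccc(SC(F)(F)F)cc2s1`: 8 mg/kg
compound 2, `C#CCn1c(=N)sc2cc(OC(F)(F)F)ccc21`: 4 mg/kg

Within the data shown here, both compounds have been tested in a functional assay on the whole organism with Rattus norvegicus as the target; a higher number here means that more compound is needed for the effect, a lower number that less compound is needed. In this assay compound 2 gives 4 mg/kg, and compound 1 gives 8 mg/kg. Among the measured compounds shown here, the two numbers lie within the usual scatter of each other, so neither compound can be set apart from the other on the dose needed, and no single structural step links them that would allow a step size to be read off.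

Compound 3, `C[S+]([O-])CCn1c(=N)sc2cc(OC(F)(F)F)ccc21`, has not yet been measured in this assay. It differs from compound 2 in one place: a group of 4 heavy atoms (2 carbon, 1 oxygen, 1 sulfur; no ring) in place of a group of 2 heavy atoms (2 carbon; no ring), on a saturated chain carbon bound to an aromatic nitrogen. The change sits on a saturated chain carbon bound to an aromatic nitrogen; the shared core of compound 2 is kept unchanged.

For the measured compounds named here, no measured step shows what a change at that chain does to the dose. The expected step is a 1.8-fold higher number from compound 2 to compound 3 (0.24 log units; within the scatter), a small move toward a higher dose that may well stay within the scatter of repeated measurements. Compound 3 is expected to give 7 mg/kg, with a range from 2.5 mg/kg to 20 mg/kg.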

Compound 3, dose for half-maximal effect: 1.1 mg/kg
Beside the measured number, compound 3's estimate is 6.4-fold (0.80 log units) above it; measured number below the stated range.
By their numbers in this assay, from the lowest: compound 3; then compounds 2 and 1 (each within the scatter of the next).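

In this assay, among these compounds, replacing ethynyl with the group of 4 heavy atoms (2 carbon, 1 oxygen, 1 sulfur; no ring), on a saturated chain carbon bound to an aromatic nitrogen, gives a 3.6-fold lower number from compound 2 to compound 3 (0.56 log units; beyond the scatter), the first step that can be read at this place. The dose therefore responds to what is carried on this chain, and the change is a favourable one: it gives up the triple bond, adds 1 hydrogen-bond acceptor and lowers the dose needed beyond the scatter. No measurement available here bears on the reason for this step.

A single step cannot show whether the sulfur and oxygen atoms or the added chain length goes with the lower dose; a plain propyl chain, the matching thioether and the matching sulfone at the same place would separate these readings. From the compounds shown here alone, it also remains open whether other kinds of group on this chain, such as an amine or a carboxylic acid, would move the dose in the same direction.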